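Chloro to bromo on the sulfonyl aryl across two cores

The compounds below may be only part of what the source reports. "The series", "measured", "known", "first", "only" and "open" are said of these compounds alone.

Compound 1 `O=C1/C(=C/c2ccccc2F)CN(S(=O)(=O)c2ccc(Cl)cc2)C/C1=C\c1ccccc1F` and compound 2 `O=C1/C(=C/c2ccccc2F)CN(S(=O)(=O)c2ccc(Br)cc2)C/C1=C\c1ccccc1F` share one core; compound 3 `O=C1/C(=C/c2ccc(F)cc2)CN(S(=O)(=O)c2ccc(Cl)cc2)C/C1=C\c1ccc(F)cc1` has the same atoms joined differently, and the difference between the two cores is not broken down here. Compound 4 `O=C1/C(=C/c2ccc(F)cc2)CN(S(=O)(=O)c2ccc(Br)cc2)C/C1=C\c1ccc(F)cc1` is not yet measured. In a functional assay on SMMC-7721 cells (Homo sapiens) for cytotoxicity, read by MTT assay, with a stated time of 24 h (on this read-out lower numbers stand for stronger inhibition and higher numbers for weaker inhibition), compound 1 gives 4500 nM, compound 2 gives 5200 nM and compound 3 gives 7000 nM. The change from compound 1 to compound 2 is bromo in place of chloro on an aromatic carbon; it made a 1.2-fold higher number from compound 1 to compound 2 (0.06 log units; within the scatter). The same change, (bromo in place of chloro on an aromatic carbon), is made on the other core, at a place described in identical words. Among the compounds with values here, the step from compound 3 to compound 4 is expected to be a 1.1-fold higher number from compound 3 to compound 4 (0.06 log units; within the scatter), resting on the single earlier step of a 1.2-fold higher number from compound 1 to compound 2 (0.06 log units; within the scatter). Compound 4 is therefore estimated at 8000 nM in this assay, with a likely range from 4000 nM to 16000 nM.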

Compound 4, half-maximal inhibitory concentration: 11500 nM
Compound 4: middle estimate off by 1.4-fold (0.16 log units), on the low side, within the range that was stated.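

Replacing 4-chlorophenyl with 4-bromophenyl in this assay gives a 1.6-fold higher number from compound 3 to compound 4 (0.22 log units; within the scatter). Set beside the earlier step, the change carries from one core to the other with no difference that can be told apart: the same change on two cores in this assay, a 1.2-fold higher number (0.06 log units; within the scatter) from compound 1 to compound 2 and a 1.6-fold higher number (0.22 log units; within the scatter) from compound 3 to compound 4, 1.4-fold (0.15 log units) apart, within the scatter of two such steps. This shows only that, for these two pairs in this one assay, the swap leaves each number within the scatter; it does not show that the two steps are truly equal, nor that the same would hold on another core or in another cell line.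

Only chloro and bromo appear at this place on the aromatic ring. Going by these compounds, whether a methoxy group, a nitrile or an amine there would shift the number beyond the scatter stays open.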